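A few compounds are considered here, and "the series" means these few. Any claim that something is new, unique, unknown or untested is made for them only; others in the source may bear on it.

Measured so far:
Compound 1, `CC(C)C(=O)N1CC2CC(C1)N2` — 20000 nM
Compound 2, `C[C@@H]1C[C@@H]1C(=O)N1CC2CC(C1)N2` — 3800 nM

In an assay on SH-EP1 cells for agonist activity at Neuronal acetylcholine receptor; alpha4/beta2 (Homo sapiens), read by FLIPR and calcium flux (a higher number here means that more compound is needed for the effect, a lower number that less compound is needed), compound 1 gives 20000 nM, and compound 2 gives 3800 nM. Among the compounds with values here, compound 2 therefore stands at the lowest number of the two, with compound 1 the only neighbour, and the single measured step, a 5.3-fold lower number from compound 1 to compound 2 (0.72 log units; beyond the scatter), is modest in size. Compound 3, `C[C@H]1C[C@@H]1C(=O)N1CC2CC(C1)N2`, keeps every atom and bond of compound 2; the difference is the two compounds have the same atoms and bonds; at least one stereo element is drawn with a configuration in one of them and without one in the other: 1 of 4 stereo elements differ; a stereocentre at a saturated ring carbon is drawn R in compound 2 and S in compound 3. In plain terms, compound 3 is a stereoisomer of compound 2, with one corner of the small three-membered ring drawn the other way round. Within the data shown here, no measured step turns a stereocentre, so the only step available, the exchange of an acyl group on the carbonyl carbon, does not speak to this change, and the direction is open. With nothing to push the expectation either way, the number for compound 3 is expected to sit close to that of compound 2, giving an estimated step of no change at the digits printed from compound 2 to compound 3 (within the scatter), but with a wide margin to either side. The estimate for compound 3 in this assay is 3800 nM, between 900 nM and 16000 nM.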

Compound 3, half-maximal effective concentration: 14000 nM
For compound 3 the middle estimate is 3.7-fold (0.57 log units) below the measured one, within the range that was stated.
By their numbers in this assay, from the lowest: compound 2; then compounds 3 and 1 (each within the scatter of the next).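

In this assay, the arrangement of the small ring in space matters, and not only its presence: with the same atoms and bonds on both sides, the result is a 3.7-fold higher number from compound 2 to compound 3 (0.57 log units; beyond the scatter). The earlier gain on going from isopropyl to 2-methylcyclopropyl therefore does not hold for every drawn form of that group, as the other form gives a 1.4-fold lower number from compound 1 to compound 3 (0.15 log units; within the scatter), so compound 3 shows no separation from compound 1 and only compound 2 stands apart. Reading this as the effect of turning one ring corner rests on a single pair of compounds, and that pair carries a caution about how the two are defined: the fact that one of compounds 2 and 3 is drawn with a defined configuration and the other without, at the place where they differ

On these data alone, it remains open whether turning the same ring corner would give a step of similar size with an ethyl or a trifluoromethyl group in place of the methyl, and where a plain cyclopropyl on the carbonyl carbon would fall. The numbers also leave open why one drawn form stands apart, and whether the same preference would hold on a different amine core.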